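A few compounds are considered here, and "the series" means these few. Any claim that something is new, unique, unknown or untested is made for them only; others in the source may bear on it.

Measured compounds:
- compound 1 `c1ccc(NC2=NCCC3(CCCCC3)S2)cc1` gives 63100 nM in a functional assay on a subcellular fraction from brain (Rattus norvegicus) for inhibition, read by scintillation counting, with a stated time of 5 min; on this read-out lower numbers stand for stronger inhibition and higher numbers for weaker inhibition
- compound 2 `FC(F)(F)c1ccc(NC2=NCCC3(CCCCC3)S2)cc1` gives 77600 nM in this assay
- compound 3 `Cc1cc(C)c(NC2=NCCC3(CCCCC3)S2)c(C)c1` gives 9300 nM in this assay

Compound 2 carries the highest of the three numbers in this assay. Its nearest neighbour is compound 1, whose number is within the scatter of that of compound 2; the furthest is compound 3, whose number sits well below that of compound 2, beyond the scatter.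

Compound 4 `Clc1ccc(NC2=NCCC3(CCCCC3)S2)cc1` differs from compound 2 by chloro in place of trifluoromethyl on an aromatic carbon. Among the measured compounds shown here, no measured pair shows a chloro entering in place of a trifluoromethyl, so the one step that bears on it is indirect: a 1.2-fold higher number from compound 1 to compound 2 (0.09 log units; within the scatter), which says that changing the substituent at this position from hydrogen to trifluoromethyl left the number essentially where it was. Compound 3 shows that a different substitution pattern on the ring can move the number, but that change is not of the kind made here.

On this basis no step beyond the scatter is expected for compound 4 in this assay, in either direction, and the estimated change is a 1.3-fold lower number from compound 2 to compound 4 (0.11 log units; within the scatter). Compound 4 is therefore expected to give about 60000 nM, with a plausible range from 25000 nM to 150000 nM.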

Compound 4, half-maximal inhibitory concentration: 35500 nM
The estimate for compound 4 lay 1.7-fold (0.23 log units) above the measured number; low and high end bracket the measured number.
By their numbers in this assay, from the lowest: compound 3; then compounds 4, 1 and 2 (each within the scatter of the next, the first and the last beyond it).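

In this assay, among the compounds shown here, the position on an aromatic carbon para to a large group proves sensitive to the choice of substituent: chloro in place of trifluoromethyl gives a 2.2-fold lower number from compound 2 to compound 4 (0.34 log units; beyond the scatter), the first single change at this position that clears the scatter, though only modestly. Chloro in place of hydrogen gives a 1.8-fold lower number from compound 1 to compound 4 (0.25 log units; within the scatter), so at this stage the separation holds only between the two substituents, and neither chloro nor trifluoromethyl stands apart from the unsubstituted compound 1. Nothing available gives a reason for the difference between chloro and trifluoromethyl.

Going by these compounds, whether a methoxy group, an amine or a carboxylic acid at this position would stay within the narrow span set by hydrogen, chloro and trifluoromethyl remains open, as does whether any of them would reach the level of compound 3, which gives 9300 nM. Which of the methyl groups of compound 3 matter for that value also stays open, since that compound differs from the others in more than one place and a single methyl group on the ring does not appear among the compounds shown.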